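Swapping the Ring on the Amine Nitrogen, Before Measurement

The compounds below may be only part of what the source reports. "The series", "measured", "known", "first", "only" and "open" are said of these compounds alone.

Measured so far:
compound 1 `Nc1scc(CN2CCN(c3ccncc3)CC2)c1C(=O)c1ccc(Cl)cc1` gives 1.4%
compound 2 `Nc1scc(CN2CCN(c3cccc(F)c3)CC2)c1C(=O)c1cccc(C(F)(F)F)c1` gives -12%

Both compounds were tested in a functional assay on CHO cells with adenosine receptor A1 (Homo sapiens) as the target, read by cAMP accumulation and immunoassay, with a stated time of 6 min, tested at 0.1 uM; a lower number here means a stronger effect, a higher number a weaker effect of the compound at the concentration tested. Compound 1 stands highest of the two numbers, with compound 1 giving 1.4% in this assay. Its nearest neighbour is compound 2, whose value in this assay, -12%, lies lower by a gap beyond the usual scatter. Among the measured compounds shown here, compound 2 differs from compound 1 in more than one place, so no single structural step between measured compounds is known here.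

The next compound is compound 3 `Nc1scc(CN2CCN(c3ccccc3Cl)CC2)c1C(=O)c1ccc(Cl)cc1`. It differs from compound 1 in one place: 2-chlorophenyl in place of pyridin-4-yl on an amine nitrogen in a ring. For the measured compounds named here, no measured pair shows such a step, and the size of the change from compound 1 to compound 3 in this assay can only be guessed. Both measured values sit near zero, so the step from compound 1 to compound 3 is expected to be small, most likely within the scatter, with a slight lean downward. Compound 3 is therefore expected to give about -3% in this assay, within a range from -20% to 12%, which means an expected step of a number 4.4 percentage points lower from compound 1 to compound 3 (within the scatter).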

Compound 3, a percentage reported as activity, at one concentration (the size of the read-out at that concentration, not a potency): 2%
Estimate against measurement, compound 3: 5 percentage points below; the range from low to high includes it.
By their numbers in this assay, from the lowest: compound 2; then compounds 1 and 3 (each within the scatter of the next).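

Among the compounds shown here, this is the first step between measured compounds that differ in one place, on the amine nitrogen in the six-membered ring. Placing 2-chlorophenyl there instead of pyridin-4-yl gives, in this assay, a number 0.6 percentage points higher from compound 1 to compound 3 (within the scatter), so this read-out does not tell the two compounds apart at the concentration tested. The exchange replaces a ring containing a nitrogen atom and counted as a hydrogen-bond acceptor with an all-carbon aromatic ring bearing chlorine and counted as having no acceptor, yet this change in ring type and substituent produces no difference that can be separated from the scatter, and no other measurement here bears on why the two compounds match.

The result comes from one pair and one concentration, so it does not show how far this position tolerates change in general, or how the two compounds would compare across a range of concentrations. It also leaves open whether a carboxylic acid, a benzyl group or a longer chain on this nitrogen would give a value that differs beyond the scatter from that of compound 1.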